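This account rests on a few compounds, and the source may have more. Where it says the series, first, only, none or still open, it means among the compounds named here.

Three ureas sharing one core have been measured in an ADME assay on the whole organism with Oryza sativa as the target, tested at 0.1 uM; a higher number here means a weaker effect of the compound at the concentration tested, a lower number a stronger effect. Compound 1 `Cc1ccc(NC(=O)N[C@@H](C)c2ccccc2)cc1` gives 100% in this assay. Compound 2 `CCc1ccc(NC(=O)N[C@@H](C)c2ccccc2)cc1` gives 99%, and compound 3 `CC(=O)c1ccc(NC(=O)N[C@@H](C)c2ccccc2)cc1` gives 99%. The steps between them are small: a number 1 percentage points lower from compound 1 to compound 2 (within the scatter), a number 1 percentage points lower from compound 1 to compound 3 (within the scatter), and no change at the digits printed from compound 2 to compound 3 (within the scatter). Among the measured compounds shown here, compound 3 therefore stands level with compound 2 at the digits printed, and its only separation from compound 1 is a single point that lies within the scatter.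

The next compound, compound 4 `C[C@H](NC(=O)Nc1ccc(Br)cc1)c1ccccc1`, differs from compound 3 in one place: bromo in place of acetyl on an aromatic carbon. The two measured steps that touch the same aromatic carbon, a number 1 percentage points lower from compound 1 to compound 3 (within the scatter) and no change at the digits printed from compound 2 to compound 3 (within the scatter), both stayed within the scatter, and no replacement at that carbon has yet moved the read-out. Whether bromo behaves like acetyl, methyl or ethyl there is not known from these three compounds, but nothing among them suggests a step beyond the scatter in this assay.

Compound 4 is accordingly expected to give 99% in this assay, with a range from 90% to 100%. This estimate means a step of no change at the digits printed from compound 3 to compound 4 (within the scatter), which is expected to stay within the scatter.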

Compound 4, a percentage reported as activity, at one concentration (the size of the read-out at that concentration, not a potency): 98%
Estimate against measurement, compound 4: 1 percentage points above, within the range that was stated.
By their numbers in this assay, from the lowest: compounds 4, 2, 3 and 1 (each within the scatter of the next).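

With bromo on this aromatic carbon, para to a large group, the substituent no longer has to contain carbon: a single bromine atom in place of the acetyl group, with its three heavy atoms, its carbonyl and its hydrogen-bond acceptor, gives a number 1 percentage points lower from compound 3 to compound 4 (within the scatter) in this assay, a step within the scatter. The same holds against the two alkyl groups, since bromo in place of ethyl gives a number 1 percentage points lower from compound 2 to compound 4 (within the scatter) and bromo in place of methyl gives a number 2 percentage points lower from compound 1 to compound 4 (within the scatter), so methyl, ethyl, acetyl and bromo cannot be told apart at this carbon in this assay, and the loss of the carbonyl and the hydrogen-bond acceptor leaves no readable mark. Nothing available bears on why the read-out stays this flat at this position.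

Still open, from the compounds shown here alone, is whether any group on this carbon can move the read-out beyond the scatter, for example an amine, a carboxylic acid, a hydroxyl or a much longer chain. The four compounds also leave open whether a change elsewhere in the shared core, such as at the urea or on the other aromatic ring, would separate compounds that this position does not.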